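Working notes: from compound 3 to compound 4

This account rests on a few compounds, and the source may have more. Where it says the series, first, only, none or still open, it means among the compounds named here.

Values below come from a functional assay on QGY-7703 cells (Homo sapiens) for cytotoxicity, read by MTT assay, with a stated time of 24 h; a higher number here means a weaker inhibitor, a lower number a stronger inhibitor.
Compound 1, `O=C1/C(=C/c2cccnc2)CN(S(=O)(=O)c2ccc(F)cc2)C/C1=C\c1ccccc1F`: 15300 nM
Compound 2, `O=C1/C(=C/c2cccnc2)CN(S(=O)(=O)c2ccc(Br)cc2)C/C1=C\c1ccccc1F`: 12800 nM
Compound 3, `N#Cc1ccc(S(=O)(=O)N2C/C(=C\c3cccnc3)C(=O)/C(=C/c3ccccc3F)C2)cc1`: 15800 nM

Compound 3 carries the highest number of the three, yet its steps to the others are within the scatter, a 1.0-fold higher number from compound 1 to compound 3 (0.01 log units; within the scatter) and a 1.2-fold higher number from compound 2 to compound 3 (0.09 log units; within the scatter), so no order among the three can be stated. The remaining step, a 1.2-fold lower number from compound 1 to compound 2 (0.08 log units; within the scatter), is likewise within the scatter. Compound 4, `N#Cc1ccc(S(=O)(=O)N2C/C(=C\c3ccncc3)C(=O)/C(=C/c3ccccc3F)C2)cc1`, differs from compound 3 in one place: pyridin-4-yl in place of pyridin-3-yl on a double-bonded chain carbon bound to a double-bonded ring carbon. Going by the values given here, none of the measured steps concerns this position; all three exchange a substituent on an aromatic carbon of a different part of the core. No step beyond the scatter is therefore expected, a 1.1-fold lower number from compound 3 to compound 4 (0.02 log units; within the scatter). Compound 4 is estimated at 15000 nM, with a range from 6000 nM to 40000 nM.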

Compound 4, half-maximal inhibitory concentration: 8500 nM
For compound 4 the middle estimate is 1.8-fold (0.25 log units) above the measured one, and the stated range covers the measured number.
By their numbers in this assay, from the lowest: compounds 4, 2, 1 and 3 (each within the scatter of the next).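

Going by these compounds alone, this is the first step read at the double-bonded chain carbon bound to a double-bonded ring carbon: in this assay, pyridin-4-yl in place of pyridin-3-yl gives a 1.9-fold lower number from compound 3 to compound 4 (0.27 log units; within the scatter), so the two pyridine attachments cannot be told apart here. As with the earlier exchanges on an aromatic carbon, no order can be stated. No evidence bears on this result.

As far as these compounds go, whether a pyridine carrying an amine or a carboxylic acid at this position would give a step beyond the scatter remains open. Also open, from the compounds shown here alone, is whether the same exchange reads alike with bromo or fluoro in place of cyano.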